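A few compounds are considered here, and "the series" means these few. Any claim that something is new, unique, unknown or untested is made for them only; others in the source may bear on it.

Measured compounds:
- compound 1, `CC(C)(C)N(NC(=O)c1ccccc1)C(=O)c1ccccc1F`: 309 nM
- compound 2, `CC(C)(C)N(NC(=O)c1ccccc1)C(=O)c1ccccc1Cl`: 75.9 nM
- compound 3, `CC(C)(C)N(NC(=O)c1ccc(F)cc1)C(=O)c1ccccc1Cl`: 389 nM

In an assay on cells for agonist activity at ecdysone receptor (Bombyx mori), read by a luciferase reporter, with a stated time of 24 h (on this read-out lower numbers stand for an effect already at smaller amounts and higher numbers for an effect only at larger amounts of compound), these three compounds, which share a core, span a modest range. From compound 1 to compound 2 the change is chloro in place of fluoro on an aromatic carbon and the step is a 4.1-fold lower number from compound 1 to compound 2 (0.61 log units; beyond the scatter). From compound 2 to compound 3 the step is a 5.1-fold higher number from compound 2 to compound 3 (0.71 log units; beyond the scatter), brought about by fluoro in place of hydrogen on an aromatic carbon. The difference between the core of compound 3 and that of compound 1 is not broken down here; their values in this assay lie within the scatter of each other.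

Compound 4, `CC(C)(C)N(NC(=O)c1ccc(Cl)cc1)C(=O)c1ccccc1Cl`, has not yet been measured. It differs from compound 3 by chloro in place of fluoro on an aromatic carbon. This is the same kind of change as that from compound 1 to compound 2, but not the same: there the chloro stands ortho to a large group, here para to a large group, and on the other ring. The earlier step therefore gives only a loose guide. He expects in this assay a step of a 1.9-fold lower number from compound 3 to compound 4 (0.29 log units; within the scatter) from compound 3 to compound 4, smaller than the earlier one because the setting differs and because compound 3 already sits at 389 nM after its own fluoro had raised the number. For compound 4 he estimates 200 nM, between 60 nM and 700 nM.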

Compound 4, half-maximal effective concentration: 115 nM
For compound 4 the middle estimate is 1.7-fold (0.24 log units) above the measured one; low and high end bracket the measured number.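

In this assay, chloro in place of fluoro on an aromatic carbon gives a 3.4-fold lower number from compound 3 to compound 4 (0.53 log units; beyond the scatter), and the change reads alike on the two cores: the same change on two cores in this assay, a 4.1-fold lower number (0.61 log units; beyond the scatter) from compound 1 to compound 2 and a 3.4-fold lower number (0.53 log units; beyond the scatter) from compound 3 to compound 4, 1.2-fold (0.08 log units) apart, within the scatter of two such steps Within these two pairs, then, the change carried over from one core to the other, even though in the newer pair it stands para to a large group on a six-membered aromatic ring of carbon only. Two pairs make no rule for the whole series and do not show why the change acts as it does, and the step for chloro in place of hydrogen at this place is a 1.5-fold higher number from compound 2 to compound 4 (0.18 log units; within the scatter), so the compounds shown give no readable difference between that chloro and hydrogen.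

The compounds shown leave open how other groups at this place, such as bromo, methyl or methoxy, would compare with fluoro and chloro. They also leave open whether the step from fluoro to chloro would keep its size on further cores, for instance one carrying a nitrile or an amine on the second ring.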